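Dipropylamide in place of the primary amide on compound 1

A few compounds are considered here, and "the series" means these few. Any claim that something is new, unique, unknown or untested is made for them only; others in the source may bear on it.

The measured compounds and their results in a functional assay on the whole organism with Mus musculus as the target; a lower number here means that less compound is needed, a higher number that more compound is needed for the effect:
compound 1 `NC(=O)Cn1c(-c2ccc(Cl)cc2)nc2cccnc21`, 4.1 mg/kg
compound 2 `NC(=O)Cn1c(-c2ccc(C(F)(F)F)cc2)nc2cccnc21`, 11.7 mg/kg
compound 3 `Cc1ccc(-c2nc3cccnc3n2CC(N)=O)cc1`, 50.5 mg/kg

Compound 1 gives the lowest number of the three in this assay. Its distance to compound 2 is a 2.9-fold higher number from compound 1 to compound 2 (0.46 log units; beyond the scatter), and to compound 3 it is a 12-fold higher number from compound 1 to compound 3 (1.09 log units; beyond the scatter); the remaining step is a 4.3-fold higher number from compound 2 to compound 3 (0.64 log units; beyond the scatter). All three steps are beyond the scatter, so compound 1 needs the least compound of the measured set.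

Compound 4 `CCCN(CCC)C(=O)Cn1c(-c2ccc(Cl)cc2)nc2cccnc21` is not yet measured. It differs from compound 1 at the carbonyl carbon: dipropylamino in place of amino on a carbonyl carbon.

Going by the values given here, none of the measured steps bears on this change. Every measured step replaces one group for another on an aromatic carbon of the side ring, while the amide in compound 1 is left untouched throughout. The measured data therefore give no guide to the direction or size of the step in this assay, and the expectation rests on the shown value of compound 1 alone. Compound 4 is expected to lie near compound 1, with a wide range, as a step of a 1.7-fold higher number from compound 1 to compound 4 (0.23 log units; within the scatter). The estimate for compound 4 in this assay is 7 mg/kg, between 1.5 mg/kg and 30 mg/kg.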

Compound 4, dose for half-maximal effect: 11 mg/kg
Compound 4: the middle estimate sits 1.6-fold (0.20 log units) below what was measured; low and high end bracket the measured number.
By their numbers in this assay, from the lowest: compound 1; then compounds 4 and 2 (each within the scatter of the next); then compound 3.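

In this assay, going by these compounds alone, this is the first change away from the side ring, and it shows that the carbonyl end of the side chain also affects the dose: dipropylamino in place of amino gives a 2.7-fold higher number from compound 1 to compound 4 (0.43 log units; beyond the scatter) and does not bring compound 4 below compound 1. The step is only modest, even though 7 heavy atoms replace 1 and the hydrogen-bond donor counted on the amino group is lost, so this position accepts a far larger group on the carbonyl carbon while the compound still gives a dose for half-maximal effect. Nothing at hand says what lies behind the rise in the number, and a single substituted amide cannot tell whether it follows from the loss of the amide hydrogen or from the two propyl chains.

Open, as far as these compounds go, is how a monopropylamide, which keeps the amide hydrogen, or a dimethylamide, with shorter chains on the same nitrogen, would stand against compound 1 and compound 4. Also open, from the compounds shown here alone, is whether trifluoromethyl or methyl on the side ring would shift the number in the same way with dipropylamino on the carbonyl carbon as they do with amino.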